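Working notes: benzylselanyl to methylselanyl on the shared core

The source may hold more compounds than are shown below. What is called first, only, known or untested is meant among the compounds shown, and "the series" means these compounds.

Measured in an ADME assay on MCF-10A cells (Homo sapiens) for cytotoxicity, read by MTT assay, with a stated time of 72 h; a lower number here means a stronger inhibitor of growth, a higher number a weaker inhibitor of growth:
compound 1, `CS/C(=N\C(=O)c1csc([N+](=O)[O-])c1)NC(=O)c1csc([N+](=O)[O-])c1`, gives 21400 nM
compound 2, `O=C(/N=C(/NC(=O)c1csc([N+](=O)[O-])c1)[Se]Cc1ccccc1)c1csc([N+](=O)[O-])c1`, gives 54100 nM

Compound 2 holds the highest of the two numbers in this assay; its nearest neighbour is compound 1, and the step of a 2.5-fold higher number from compound 1 to compound 2 (0.40 log units; beyond the scatter) lies beyond the scatter. Compound 3, `C[Se]/C(=N\C(=O)c1csc([N+](=O)[O-])c1)NC(=O)c1csc([N+](=O)[O-])c1`, is not yet measured. It differs from compound 2 by hydrogen in place of phenyl on a saturated chain carbon bound to a selenium atom. For the measured compounds named here, the only step that bears on this is the one from compound 1 to compound 2, in which a benzylselanyl group replaced a methylthio group and the number rose, a 2.5-fold higher number from compound 1 to compound 2 (0.40 log units; beyond the scatter). The move to compound 3 removes the benzyl part again while keeping selenium, so a drop of roughly that size is expected, with the step of a 2.2-fold lower number from compound 2 to compound 3 (0.34 log units; beyond the scatter). For compound 3 the expected value in this assay is 25000 nM, within 12000 nM to 52000 nM.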

Compound 3, concentration for total growth inhibition: 4740 nM
Estimate against measurement, compound 3: 5.3-fold (0.72 log units) above; the measured number lies below the stated range.
By their numbers in this assay, from the lowest: compound 3; then compound 1; then compound 2.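

In this assay, benzyl to methyl on the selenium gives an 11-fold lower number from compound 2 to compound 3 (1.06 log units; beyond the scatter), so the group on selenium has a large bearing on the number. With the methyl group held, selenium in place of sulfur gives a 4.5-fold lower number from compound 1 to compound 3 (0.65 log units; beyond the scatter), which shows that the atom exchange alone also lowers the number. The earlier step, a 2.5-fold higher number from compound 1 to compound 2 (0.40 log units; beyond the scatter), therefore combined two changes running in opposite directions, and its modest size hid the larger effect of each; no measurement here accounts for either step.

A benzylthio group on the shared core would show whether selenium lowers the number with benzyl as it does with methyl. On these data alone, whether an ethyl group or a longer chain on selenium raises the number as benzyl does also stays open.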